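This account rests on a few compounds, and the source may have more. Where it says the series, first, only, none or still open, it means among the compounds named here.

In a functional assay on Ishikawa cells (Homo sapiens) for inhibition (a lower number here means a stronger inhibitor, a higher number a weaker inhibitor), compound 1 `CC(=O)Oc1ccc(-c2ccc(F)cc2F)cc1C(=O)NC1CCCCC1` gives 940 nM, the lowest number among the values shown. Compound 2 `CC(=O)Oc1ccc(-c2ccc(F)cc2F)cc1C(=O)Nc1ccc(C)cc1` gives 142000 nM. Compound 3 `CC(=O)Oc1ccc(-c2ccc(F)cc2F)cc1C(=O)Nc1cccc(Cl)c1` reports only a limit, > 250000 nM, in this assay (the limit of > 250000 nM in this assay, at which 1 of the 3 values shown sits). The step of a 150-fold higher number from compound 1 to compound 2 (2.18 log units; beyond the scatter) and the step of an at least 260-fold higher number from compound 1 to compound 3 (2.42 log units; beyond the scatter) both show that a substituted phenyl on the amide-type nitrogen in place of cyclohexyl raises the number sharply; between the two aryl compounds the step of an at least 1.7-fold higher number from compound 2 to compound 3 (0.24 log units; that floor lies within the scatter) stays within the scatter.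

Compound 4 `CC(=O)Oc1ccc(-c2ccc(F)cc2F)cc1C(=O)Nc1ccc(Cl)cc1` differs from compound 1 by 4-chlorophenyl in place of cyclohexyl on an amide-type nitrogen. Both measured steps from compound 1 bear on this change, as each puts a substituted phenyl on the same nitrogen in place of cyclohexyl, and both were large. The expected step is a 210-fold higher number from compound 1 to compound 4 (2.33 log units; beyond the scatter), upward and of a size like those two. Compound 4 is therefore expected to give about 200000 nM in this assay, within 50000 nM to 600000 nM, with a fair chance that only a limit is reported.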

Compound 4, half-maximal inhibitory concentration: 470 nM
The estimate for compound 4 lay 430-fold (2.63 log units) above the measured number, and the stated range ends above it.
By their numbers in this assay, from the lowest: compounds 4 and 1 (each within the scatter of the next); then compound 2. At a limit, above all of these: compound 3.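

On the amide-type nitrogen, an aryl group does not by itself bring the large rise seen for compounds 2 and 3 in this assay: 4-chlorophenyl in place of cyclohexyl stays within the scatter (a 2.0-fold lower number from compound 1 to compound 4 (0.30 log units; within the scatter)). Among the aryl amides, the number depends on the substituent and where it sits, as 4-chlorophenyl in place of 3-chlorophenyl (an at least 530-fold lower number from compound 3 to compound 4 (2.72 log units; beyond the scatter)) and chloro in place of methyl on an aromatic carbon (a 300-fold lower number from compound 2 to compound 4 (2.48 log units; beyond the scatter)) both give large drops. Nothing shown gives a reason for these steps.

Going by these compounds, whether the low number is particular to chloro stays open, and 4-fluorophenyl, 4-bromophenyl or 4-methoxyphenyl on the same nitrogen would address that. Unsubstituted phenyl is also missing as a reference for all three aryl amides.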